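Replacing dimethylamino in compound 2

The source may report more compounds than this note shows. Statements on the series, on what has been measured and on what is new or still open speak of the compounds shown alone.

Measured in a toxicity assay on cells (Macrophage, Homo sapiens) for inhibition, read by MTT assay; a higher number here means a weaker inhibitor, a lower number a stronger inhibitor:
compound 1 (`CN1CCN(CCCNc2nc(-c3ccc(Cl)cc3)nc3ccccc23)CC1`): "nd" (no result reported)
compound 2 (`COc1ccc(-c2nc(NCCN(C)C)c3ccccc3n2)cc1`): 57000 nM

Within the data shown here, compound 2 holds the only number in this assay so far, and compound 1 has no result, so compound 2 has no rank and no measured neighbour. Compound 3 (`COc1ccc(-c2nc(NCCCN3CCN(C)CC3)c3ccccc3n2)cc1`) is still to be measured. Its structure differs from that of compound 2 by (4-methylpiperazin-1-yl)methyl in place of dimethylamino on a saturated chain carbon, two bonds along the chain from a nitrogen on an aromatic ring. Among the measured compounds shown here, no measured step gives a size for this change. A modest shift toward stronger inhibition is expected, with little confidence, and the estimated step is a 1.4-fold lower number from compound 2 to compound 3 (0.15 log units; within the scatter), which may prove to lie within the scatter. In this assay compound 3 is estimated at 40000 nM (expected range 12000 nM to 120000 nM).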

Compound 3, half-maximal inhibitory concentration: 53000 nM
Beside the measured number, compound 3's estimate is 1.3-fold (0.12 log units) below it; low and high end bracket the measured number.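

In this assay this change gives a 1.1-fold lower number from compound 2 to compound 3 (0.03 log units; within the scatter) as the first measured size for it. Dimethylamino (3 heavy atoms, no ring) and (4-methylpiperazin-1-yl)methyl (8 heavy atoms, one six-membered non-aromatic ring) on this saturated chain carbon, two bonds along the chain from a nitrogen on an aromatic ring, therefore show no difference beyond the scatter in this single pair. Nothing at hand gives a reason for this result.

As far as these compounds go, whether the same holds for other groups at this place remains open, for example a morpholin-4-ylmethyl group, a primary amine or a longer chain ending in dimethylamino. A single pair also cannot show whether the outcome carries over to a core bearing a different aryl group, such as 4-chlorophenyl.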